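Swapping a group on a carbonyl carbon

The source may report more compounds than this note shows. Statements on the series, on what has been measured and on what is new or still open speak of the compounds shown alone.

In a physicochemical assay for solubility (on this read-out higher numbers stand for higher solubility and lower numbers for lower solubility), compound 1 `O=C(c1ccc(Cl)cc1)N1CCC(NS(=O)(=O)c2cc(S(=O)(=O)c3ccccc3)ccc2C(F)(F)F)CC1` gives 3100 nM and compound 2 `O=C(c1cccnc1)N1CCC(NS(=O)(=O)c2cc(S(=O)(=O)c3ccccc3)ccc2C(F)(F)F)CC1` gives 50000 nM on the shared core. Compound 3 `CN(C)c1ccc(C(=O)N2CCC(NS(=O)(=O)c3cc(S(=O)(=O)c4ccccc4)ccc3C(F)(F)F)CC2)cn1` gives the middle number of the three (12500 nM). Compound 4 `CC(C)(C)OC(=O)N1CCC[C@@H]1C(=O)N1CCC(NS(=O)(=O)c2cc(S(=O)(=O)c3ccccc3)ccc2C(F)(F)F)CC1` has 1-(tert-butoxycarbonyl)pyrrolidin-2-yl in place of 6-(dimethylamino)pyridin-3-yl on a carbonyl carbon. Swaps on that carbon gave a 16-fold higher number from compound 1 to compound 2 (1.21 log units; beyond the scatter) and a 4.0-fold higher number from compound 1 to compound 3 (0.61 log units; beyond the scatter) while dimethylamino in place of hydrogen on an aromatic carbon gave a 4.0-fold lower number from compound 2 to compound 3 (0.60 log units; beyond the scatter) as a further move. In none of these steps does a non-aromatic group enter, so they suggest a size but no direction. A small drop within the scatter is therefore expected (a 1.4-fold lower number from compound 3 to compound 4 (0.14 log units; within the scatter)). For compound 4 the estimated value is 9000 nM with an expected range from 2500 nM to 35000 nM around it.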

Compound 4, solubility: 25000 nM
Compound 4: the middle estimate sits 2.8-fold (0.44 log units) below what was measured; the range from low to high includes it.
By their numbers in this assay, from the lowest: compound 1; then compounds 3, 4 and 2 (each within the scatter of the next, the first and the last beyond it).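

Compound 4 is the only one of the four with a non-aromatic group on this carbonyl carbon, and in this assay it stands level with the two pyridine compounds (a 2.0-fold higher number from compound 3 to compound 4 (0.30 log units; within the scatter); a 2.0-fold lower number from compound 2 to compound 4 (0.30 log units; within the scatter)). The gap to the 4-chlorophenyl compound remains clear (an 8.1-fold higher number from compound 1 to compound 4 (0.91 log units; beyond the scatter)), so an aromatic ring is not required here to reach this level. No measured finding on hand accounts for this result.

Open, from the compounds shown here alone, is whether the pyrrolidine ring or the tert-butoxycarbonyl group matters more. A free pyrrolidine amine on this carbon would separate the two.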